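Butoxy to (Difluoromethyl)sulfanyl: Expected Cytotoxicity of Compound 4

The source may hold more compounds than are shown below. What is called first, only, known or untested is meant among the compounds shown, and "the series" means these compounds.

Compound 1 `Cc1ccc2[nH]c(=O)c(CN(Cc3ccc(F)cc3)Cc3ccc(C(C)(C)C)cc3)cc2c1`: > 27000 nM, a limit of the assay.
Compound 2 `Cc1ccc2[nH]c(=O)c(CN(Cc3ccc(OCC(=O)O)cc3)Cc3ccc(C(C)(C)C)cc3)cc2c1`: > 10000 nM, a limit of the assay.
Compound 3 `CCCCOc1ccc(CN(Cc2ccc(C(C)(C)C)cc2)Cc2cc3cc(C)ccc3[nH]c2=O)cc1`: > 5000 nM, a limit of the assay.

All three compounds share one core and differ only in the group on one benzyl ring. In a toxicity assay on MDCK cells (Canis lupus familiaris) for cytotoxicity, read by crystal violet staining, with a stated time of 48 h (on this read-out higher numbers stand for lower toxicity in this test and lower numbers for higher toxicity in this test), none of them gives a number: every reported value is a limit. Compound 3 stands at the limit of > 5000 nM in this assay, at which 1 of the 3 values shown sits, and the other two values are limits as well, the limit of > 10000 nM in this assay, at which 1 of the 3 values shown sits, and (the limit of > 27000 nM in this assay, at which 1 of the 3 values shown sits). The steps a step that the two limits leave unreadable from compound 1 to compound 3 and a step that the two limits leave unreadable from compound 2 to compound 3 therefore cannot be read in size or direction, and nothing says whether any of these three is more or less toxic than another.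

Compound 4 `Cc1ccc2[nH]c(=O)c(CN(Cc3ccc(SC(F)F)cc3)Cc3ccc(C(C)(C)C)cc3)cc2c1` differs from compound 3 by (difluoromethyl)sulfanyl in place of butoxy on an aromatic carbon. Going by the values given here, no measured step bears readably on this change, since each of the neighbouring comparisons ends at a limit. Because compound 3 and its neighbours all sit at a limit (the limit of > 5000 nM in this assay, at which 1 of the 3 values shown sits), compound 4 is expected to be reported as a limit too, with no step beyond the scatter. The expected step is a step that the limit leaves unreadable from compound 3 to compound 4. Compound 4 is estimated at 20000 nM, within a range from 5000 nM to 80000 nM.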

Compound 4, half-maximal cytotoxic concentration: > 5000 nM
Compound 4 ended at the assay's limit; the forecaster's own chance of this, stated with the estimate: 80%; the middle value does not contradict the limit.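

In this assay compound 4 gives > 5000 nM, a limit of the assay. Its steps to compound 1, compound 2 and compound 3 all end at limits and cannot be read in size or direction. The compounds shown leave open how toxic each of the four is, and whether changing the group on the benzyl ring alters that toxicity at all.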